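The compounds below may be only part of what the source reports. "The series", "measured", "known", "first", "only" and "open" are said of these compounds alone.

Measured compounds:

Compound 1, `Nc1sc2cnccc2c1C(=O)c1ccccc1Cl`; in an assay on CHO cells for displacement of a labelled ligand from adenosine receptor A1 (Homo sapiens), tested at 10 uM (on this read-out lower numbers stand for less inhibition and higher numbers for more inhibition at the one concentration tested (going by the name of the read-out)), compound 1 gives 0%.
Compound 2, `Nc1sc2cnccc2c1C(=O)c1ccc(Cl)c(Cl)c1`; in this assay compound 2 gives 0%.
Compound 3, `Nc1sc2cnccc2c1C(=O)c1ccc(Br)cc1`; in this assay compound 3 gives 0%.

The three measured compounds share one core and differ only in the substitution of the six-membered aromatic ring of carbon only attached to the carbonyl. On the numbers shown, compound 3 stands level with compound 1 and compound 2: all three read the same at the digits reported, and the gaps between them lie within the scatter of this kind of measurement. Nothing in this set separates one substitution pattern from another.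

Compound 4, `COc1ccc(C(=O)c2c(N)sc3cnccc23)cc1`, has not yet been measured. It differs from compound 3 in one place: methoxy in place of bromo on an aromatic carbon. The bromo leaves and a methoxy enters, para to a large group.

For the measured compounds named here, no step between measured compounds is available, and the three values give no direction to follow. The expected step in this assay from compound 3 to compound 4 is therefore none beyond the scatter, no change at the digits printed from compound 3 to compound 4 (within the scatter). Compound 4 is estimated at 0%, within a range from 0% to 10%.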

Compound 4, a percentage reported as inhibition, at one concentration (the size of the read-out at that concentration, not a potency): 0%
The estimate for compound 4 equals the measured number at the digits printed; the range from low to high includes it.
By their numbers in this assay, from the lowest: compounds 1, 2, 3 and 4 (each within the scatter of the next).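

For the compounds shown here, the first step between two compounds differing in one place shows that in this assay, replacing bromo with methoxy on an aromatic carbon, para to a large group, gives no change at the digits printed from compound 3 to compound 4 (within the scatter). Going by these compounds alone, the earlier compounds offered no such pair, so this is the first direct reading of a single change at this position: one heavy atom gives way to two, and a hydrogen-bond acceptor is added, with no difference in the read-out. No measurement bears on why the read-out stays the same here.

The compounds shown leave open whether any group at this position can raise the reading, since all four give the same value and a single step covers only this one exchange. An amine, a carboxylic acid or a longer chain such as butoxy in this place remains untested in the compounds shown, as does any change to the shared core.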